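The compounds below may be only part of what the source reports. "The series", "measured", "known", "first", "only" and "open" are said of these compounds alone.

Working notes on the series. In a functional assay on BT-474 cells (Homo sapiens) for inhibition, read by fluorescence, with a stated time of 72 h (a higher number here means a weaker inhibitor of growth, a lower number a stronger inhibitor of growth), compound 2 (`CCCCn1cnc2c(NCc3cccc(Cl)c3)nc(N[C@H]3CC[C@H](N)CC3)nc21`) gives 4700 nM, compound 3 (`CC(C)CCn1cnc2c(NCc3cccc(Cl)c3)nc(N[C@H]3CC[C@H](N)CC3)nc21`) gives 6600 nM and compound 1 (`COc1ccc(Cn2cnc3c(Nc4cccc(Cl)c4)nc(N[C@H]4CC[C@H](N)CC4)nc32)cc1`) gives 8200 nM. Compound 2 stands within the scatter of both others, so these numbers give it no rank.

Compound 4 (`CCCCn1cnc2c(Nc3cc(OC)cc(OC)c3)nc(N[C@H]3CC[C@H](N)CC3)nc21`) is the next to be read in this assay. The change from compound 2 is 3,5-dimethoxyphenyl in place of 3-chlorobenzyl on a nitrogen on an aromatic ring.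

For the measured compounds named here, the only measured step, a 1.4-fold higher number from compound 2 to compound 3 (0.15 log units; within the scatter), is methyl in place of hydrogen on a saturated chain carbon bound to two saturated chain carbons. It lies elsewhere in the molecule and says little about this nitrogen. Compound 1 differs from compound 2 in more than one place, so compound 1 at 8200 nM isolates no single change. Going by the values given here, no measured step covers a replacement at this nitrogen, and the data give no direction for one.

The expectation therefore stays anchored on compound 2 at 4700 nM, with no shift expected beyond the scatter and a wide margin for the untested change. The estimated step is a 1.1-fold higher number from compound 2 to compound 4 (0.03 log units; within the scatter). For compound 4 the expected value is 5000 nM, with an estimated range of 1500 nM to 15000 nM.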

Compound 4, concentration for 50% growth inhibition: 15600 nM
For compound 4 the middle estimate is 3.1-fold (0.49 log units) below the measured one, outside the stated range (above it).
By their numbers in this assay, from the lowest: compounds 2, 3, 1 and 4 (each within the scatter of the next, the first and the last beyond it).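

In this assay, for the compounds shown here, the exchange at this nitrogen gives the only step that lies beyond the scatter: a 3.3-fold higher number from compound 2 to compound 4 (0.52 log units; beyond the scatter). Going by these compounds alone, the group on a nitrogen on an aromatic ring therefore registers in this read-out for the butyl compounds, whereas the one earlier step, a 1.4-fold higher number from compound 2 to compound 3 (0.15 log units; within the scatter), sits on a saturated chain carbon and stays within the scatter. The step shows only that 3,5-dimethoxyphenyl reads weaker than 3-chlorobenzyl here, and nothing available bears on why.

This single exchange alters several things at once, since the benzyl becomes a phenyl and the chlorine gives way to methoxy groups, so the compounds shown do not assign the step to any one of these. On these data alone, a plain benzyl or a 3,5-dimethoxybenzyl on this nitrogen, with the butyl chain and the rest of the core of compound 2 held fixed, would show whether the difference follows the ring's attachment or its substituents, and how far this nitrogen tolerates change in either direction remains open.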